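Trading diethylamino for piperidin-1-yl on one core

The source may hold more compounds than are shown below. What is called first, only, known or untested is meant among the compounds shown, and "the series" means these compounds.

In a toxicity assay on HFF-1 cells (Homo sapiens) for cytotoxicity, read by WST assay, with a stated time of 72 h (on this read-out higher numbers stand for weaker inhibition and lower numbers for stronger inhibition), compound 1 `CCN(CC)CC#CCSc1nc2c(c(=O)[nH]c(=O)n2C)n1C` gives 3680 nM. Compound 2 `Cn1cnc2nc(SCC#CCN3CCCCC3)nc(SCC#CCN3CCCCC3)c21` gives 3980 nM, and these two numbers lie within the usual scatter of each other, so neither stands apart. Compound 3 `Cn1c(SCC#CCN2CCCCC2)nc2c1c(=O)[nH]c(=O)n2C` has not yet been measured. It keeps the core of compound 1 and changes one group: piperidin-1-yl in place of diethylamino on a saturated chain carbon bound to a triple-bonded carbon. In words, piperidin-1-yl sits in place of diethylamino on a saturated chain carbon bound to a triple-bonded carbon. Among the compounds with values here, no measured pair shows this change alone, so the data give no direct guide. Within the data shown here, the only hint is compound 2, which also carries piperidin-1-yl and stays close at 3980 nM. In this assay, the expected step of a 1.0-fold higher number from compound 1 to compound 3 (0.01 log units; within the scatter) is therefore none beyond the scatter. For compound 3 the estimated value is 3800 nM, with an expected range from 1800 nM to 8000 nM.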

Compound 3, half-maximal inhibitory concentration: 30400 nM
Compound 3: the middle estimate sits 8.0-fold (0.90 log units) below what was measured; the measured number lies above the stated range.
By their numbers in this assay, from the lowest: compounds 1 and 2 (each within the scatter of the next); then compound 3.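

In this assay, the amine at this place is not a spot where one group can be swapped freely for another: piperidin-1-yl in place of diethylamino on a saturated chain carbon bound to a triple-bonded carbon gives (an 8.3-fold higher number from compound 1 to compound 3 (0.92 log units; beyond the scatter)), which means weaker inhibition of the cells. The swap looks small on paper, going from 5 heavy atoms with no ring to 6 heavy atoms in one six-membered non-aromatic ring, yet the step lies beyond the scatter. Nothing given here explains this step.

From the compounds shown here alone, whether the ring or the added carbon carries the step stays open, and a group such as pyrrolidin-1-yl, morpholin-4-yl or dimethylamino at this place could help separate the two. Going by these compounds, it is also open whether the same swap would act alike on another core, since compound 2 differs from compound 3 in more than one place.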